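The source may report more compounds than this note shows. Statements on the series, on what has been measured and on what is new or still open speak of the compounds shown alone.

Measured so far:
compound 1 `COc1cc(NC(=O)Nc2ccc([N+](=O)[O-])cc2)cc(OC)c1OC` — 35000 nM
compound 2 `COc1cc(N(C)C(=O)N(C)c2cccc([N+](=O)[O-])c2)cc(OC)c1OC` — >= 125000 nM
compound 3 `COc1cc(N(C)C(=O)N(C)c2ccccc2)cc(OC)c1OC` — "not determined" (no result reported)

For the measured compounds named here, in a functional assay on ONS-76 cells (Homo sapiens) for cytotoxicity, read by MTT assay, with a stated time of 72 h (a higher number here means a weaker inhibitor, a lower number a stronger inhibitor), compound 1 gives 35000 nM, the only plain number among the three. Compound 2 gives only a limit of the assay, not a number, >= 125000 nM; this is the limit of >= 125000 nM in this assay, at which 1 of the 3 values shown sits. Compound 3 gives "not determined" (no result reported). Compound 4 `COc1ccc(NC(=O)Nc2cc(OC)c(OC)c(OC)c2)cc1` has not yet been measured. It differs from compound 1 in one place: methoxy in place of nitro on an aromatic carbon. Going by the values given here, no measured pair differs in only one spot, so no known step size can be leaned on. Since compound 1 is already a weak inhibitor, methoxy in place of nitro is expected to shift this assay little, if anything toward weaker. Compound 4 is therefore expected to give 50000 nM, between 15000 nM and 150000 nM, an estimated step of a 1.4-fold higher number from compound 1 to compound 4 (0.15 log units; within the scatter).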

Compound 4, half-maximal inhibitory concentration: 12900 nM
For compound 4 the middle estimate is 3.9-fold (0.59 log units) above the measured one, and the stated range ends above it.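

Swapping nitro for methoxy on this aromatic carbon, para to a large group, gives a 2.7-fold lower number from compound 1 to compound 4 (0.43 log units; beyond the scatter) in this assay. This first single-place comparison shows that the group held here matters, and the change leads to a stronger inhibitor, although compound 4 remains weak at 12900 nM. Nothing shown here explains the step.

With only these two groups compared at this position, no trend across groups can be drawn. An amine, a carboxylic acid or a longer alkoxy chain here could move the number either way.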